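The source may report more compounds than this note shows. Statements on the series, on what has been measured and on what is new or still open speak of the compounds shown alone.

Of the compounds shown here, three built on one shared core have been tested in a functional assay on the whole organism for inhibition, with Rattus norvegicus as the target, read by paw edema, at a dose of 100 mg/kg by the oral route; on this read-out lower numbers stand for less inhibition and higher numbers for more inhibition at the one dose given (going by the name of the read-out). Compound 1 `CCOC(=O)c1c(O)c2cccnc2n(-c2ccccc2)c1=O` gives 23.5%, the highest of the three numbers. Compound 2 `O=C(Nc1ccccn1)c1c(O)c2cccnc2n(-c2ccccc2)c1=O` gives -13.5%, and compound 3 `Cc1ccc(NC(=O)c2c(O)c3cccnc3n(-c3ccccc3)c2=O)cc1` gives -3.5%. Both measured steps away from compound 1 swap out the same ethoxy group for a nitrogen-linked aromatic ring: a number 37 percentage points lower from compound 1 to compound 2 (beyond the scatter) and a number 27 percentage points lower from compound 1 to compound 3 (beyond the scatter). Between the two amides the gap is small: a number 10 percentage points higher from compound 2 to compound 3 (within the scatter).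

Compound 4 `O=C(Nc1ccc([N+](=O)[O-])cc1)c1c(O)c2cccnc2n(-c2ccccc2)c1=O` has not yet been measured. It differs from compound 1 in one place: (4-nitrophenyl)amino in place of ethoxy on a carbonyl carbon. The two measured steps that replaced the ethoxy group both bear directly on this change, and both fell beyond the scatter in the same direction, so a clear drop in this assay is expected here as well, of a size comparable to those two steps. The step that is expected is a number 31.5 percentage points lower from compound 1 to compound 4 (beyond the scatter). For compound 4 the estimated read-out in this assay is -8%, with a range from -30% to 14%.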

Compound 4, a percentage reported as inhibition, in the whole organism at one dose (the size of the read-out at that dose, not a potency): -7.6%
Compound 4: middle estimate off by 0.4 percentage points, on the low side, and the stated range covers the measured number.
By their numbers in this assay, from the lowest: compounds 2, 4 and 3 (each within the scatter of the next); then compound 1.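

In this assay, a third amide falls with the other two: the step is a number 31.1 percentage points lower from compound 1 to compound 4 (beyond the scatter), so the drop on replacing ethoxy on this carbonyl carbon now holds for all three nitrogen-linked aromatic groups shown. Changing the aromatic group on the amide makes no readable difference, with a number 4.1 percentage points lower from compound 3 to compound 4 (within the scatter) for nitro in place of methyl on an aromatic carbon and a number 5.9 percentage points higher from compound 2 to compound 4 (within the scatter) for 4-nitrophenyl in place of pyridin-2-yl. Nothing measured here accounts for the drop.

As far as these compounds go, whether it comes from the amide link itself or from the aromatic ring on it stays open, and a plain amino group or a carboxylic acid on this carbonyl carbon would help separate the two. A longer chain such as butoxy in place of ethoxy would show whether the number of compound 1 can be raised.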